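The compounds below may be only part of what the source reports. "The series", "measured", "known", "first", "only" and "open" are said of these compounds alone.

Measured compounds in a functional assay on CCRF-CEM cells (Homo sapiens) for inhibition, read by cell counting, with a stated time of 3 days; a higher number here means a weaker inhibitor, a lower number a stronger inhibitor:

compound 1 `COc1cccc(-c2nn3cc(-c4cccc(N)c4)nc3s2)c1`: > 250000 nM, a limit of the assay, not a number
compound 2 `C=C(Br)C(=O)Nc1cccc(-c2cn3nc(-c4ccc(C)cc4)sc3n2)c1`: 1700 nM
compound 3 `Nc1cccc(-c2cn3nc(-c4ccc(F)cc4)sc3n2)c1`: >= 250000 nM, a limit of the assay, not a number

Among the measured compounds shown here, compound 2 stands as the only compound with an actual number in this assay; the two other values shown are limits. Compound 1 sits at the limit of > 250000 nM in this assay, at which 1 of the 3 values shown sits. Compound 3 sits at the limit of >= 250000 nM in this assay, at which 1 of the 3 values shown sits. For the measured compounds named here, no step between two measured compounds that differ in one place is available, so the two limits and the one number say only that compound 2 is the one that inhibits within the measurable window.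

Compound 4 `C=C(Br)C(=O)Nc1cccc(-c2cn3nc(Cc4ccccc4)sc3n2)c1` is the next compound to be measured in this assay. It differs from compound 2 in this way: benzyl in place of 4-methylphenyl on an aromatic carbon. The bromoacrylamide side of compound 2 is kept unchanged.

Since compound 2 is the only number shown, the step to compound 4 cannot be anchored to a measured step of the same kind. The swap keeps the atom count and only rearranges how the seven carbons are joined, so a modest loss is the expectation, with a fair chance that the change stays within the scatter. The estimate for compound 4 is 4500 nM, with a range from 1000 nM to 20000 nM. This means an expected step of a 2.6-fold higher number from compound 2 to compound 4 (0.42 log units; beyond the scatter), estimated rather than measured.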

Compound 4, half-maximal inhibitory concentration: 4200 nM
Compound 4: the middle estimate sits 1.1-fold (0.03 log units) above what was measured, within the range that was stated.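

In this assay, among the compounds shown here, benzyl in place of 4-methylphenyl gives the first reading of this position (a 2.5-fold higher number from compound 2 to compound 4 (0.39 log units; beyond the scatter)), with the bromoacrylamide side held constant. The two groups have the same atoms, so the step shows that their arrangement on the aromatic carbon next to the ring sulfur alters the result, yet only modestly: compound 4 still gives a real number (4200 nM), not a limit of the assay, and the 4-methylphenyl group is therefore not required for a measurable value in this pair. No available evidence bears on why this rearrangement produces the step.

The compounds shown give a single step at this position, so it remains open whether the trend extends to a longer chain such as 2-phenylethyl, or to a group of another kind such as an amine or a carboxylic acid. From the compounds shown here alone, it also remains open whether benzyl and 4-methylphenyl would differ to the same extent if the bromoacrylamide were replaced by a plain acrylamide.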